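The source may report more compounds than this note shows. Statements on the series, on what has been measured and on what is new or still open speak of the compounds shown alone.

Compound 1 `COc1cc2c(cc1N1CCN[C@@H](C)C1)N(S(=O)(=O)c1ccc(-c3ccccn3)s1)CC2` and compound 2 `COc1cc2c(cc1N1CCNCC1)N(S(=O)(=O)c1ccc(-c3ccccn3)s1)CC2` share one core and differ only at a single carbon of the saturated ring attached to it. For the measured compounds named here, in a functional assay for agonist activity at growth hormone secretagogue receptor type 1 (Homo sapiens), read by FLIPR (a higher number here means that more compound is needed for the effect, a lower number that less compound is needed), compound 1 gives 3.16 nM, while compound 2 gives 63.1 nM, the highest of the two numbers measured so far; the change is a 20-fold higher number from compound 1 to compound 2 (1.30 log units; beyond the scatter). Compound 3 `COc1cc2c(cc1N1C[C@@H](C)NC(C)(C)C1)N(S(=O)(=O)c1ccc(-c3ccccn3)s1)CC2` has not yet been measured. It differs from compound 2 in that (a group of 9 heavy atoms (7 carbon, 2 nitrogen; one six-membered non-aromatic ring with 2 hetero atoms) in place of a group of 6 heavy atoms (4 carbon, 2 nitrogen; one six-membered non-aromatic ring with 2 hetero atoms), on an aromatic carbon). Going by the values given here, the only measured step that bears on this change is the one from compound 1 to compound 2, where removing the methyl from the saturated ring raised the number by a large amount; compound 3 restores a methyl at a stereocentre and adds further methyl groups on another ring carbon, which the measured data do not cover. The expected step is therefore a 7.9-fold lower number from compound 2 to compound 3 (0.90 log units; beyond the scatter), toward a lower number. The estimate for compound 3 is 8 nM, within a range from 2 nM to 40 nM.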

Compound 3, half-maximal effective concentration: 10 nM
Beside the measured number, compound 3's estimate is 1.3-fold (0.10 log units) below it; the range from low to high includes it.
By their numbers in this assay, from the lowest: compound 1; then compound 3; then compound 2.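

Methyl groups on the piperazine ring can do more than the single methyl of compound 1 suggested, since the ring of compound 3, with its added methyl groups and one defined stereocentre, recovers much of the loss seen with the unsubstituted piperazin-1-yl group in this assay (a 6.3-fold lower number from compound 2 to compound 3 (0.80 log units; beyond the scatter)). Even so, the more heavily substituted ring does not match the simpler one, and the step is modest but beyond the scatter (a 3.2-fold higher number from compound 1 to compound 3 (0.50 log units; beyond the scatter)), so adding methyl groups here does not keep lowering the number. No supporting measurement is available to explain either step.

The three compounds leave open how much each methyl group contributes and how much depends on the stereocentre. They also leave open whether an ethyl or hydroxymethyl group on the same ring would be accepted.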